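From 4-cyanophenyl to 6-methoxypyridin-3-yl on the shared core

A few compounds are considered here, and "the series" means these few. Any claim that something is new, unique, unknown or untested is made for them only; others in the source may bear on it.

Measured in a functional assay on MDA-MB-231 cells (Homo sapiens) for antiproliferative activity, read by MTT assay, with a stated time of 48 h; a lower number here means a stronger inhibitor, a higher number a weaker inhibitor:
Compound 1 `C=CS(=O)(=O)N1CCN(c2ncnc3sc(-c4ccc(OC)nc4)cc23)CC1`: 9270 nM
Compound 2 `C=CS(=O)(=O)N1CCN(c2nc(OC[C@H]3CCCN3C)nc3sc(-c4ccc(C#N)cc4)cc23)CC1`: 3010 nM
Compound 3 `C=CS(=O)(=O)N1CCN(c2nc(OCC3CCCCN3C)nc3sc(-c4ccc(C#N)cc4)cc23)CC1`: 3180 nM

Compound 2 stands together with compound 3 at the low end of these numbers, and compound 1 carries a higher number than either. Compound 4 `C=CS(=O)(=O)N1CCN(c2nc(OC[C@H]3CCCN3C)nc3sc(-c4ccc(OC)nc4)cc23)CC1` has not yet been measured. It departs from compound 2 in one place, with 6-methoxypyridin-3-yl in place of 4-cyanophenyl on an aromatic carbon.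

Among the measured compounds shown here, no measured step covers this exchange. The only one available, a 1.1-fold higher number from compound 2 to compound 3 (0.02 log units; within the scatter), concerns the 1-methylpyrrolidin-2-yl group and not the 4-cyanophenyl group. Compound 1 does carry the 6-methoxypyridin-3-yl group, and it gives 9270 nM, but it also lacks the 1-methylpyrrolidin-2-yl group of compound 4, so its value cannot isolate the exchange. No shift beyond the scatter is therefore expected in this assay, although this expectation is weakly supported. The expected size is a 1.0-fold lower number from compound 2 to compound 4 (0.00 log units; within the scatter). Compound 4 is estimated at 3000 nM, with an expected range of 1000 nM to 9000 nM.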

Compound 4, half-maximal inhibitory concentration: 3560 nM
The estimate for compound 4 lay 1.2-fold (0.07 log units) below the measured number; the measured number falls inside the stated range.
By their numbers in this assay, from the lowest: compounds 2, 3 and 4 (each within the scatter of the next); then compound 1.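

In this assay, the exchange on the aromatic carbon next to the ring sulfur gives a 1.2-fold higher number from compound 2 to compound 4 (0.07 log units; within the scatter), so with the (1-methylpyrrolidin-2-yl)methoxy group present, 4-cyanophenyl and 6-methoxypyridin-3-yl cannot be told apart here. Among the compounds shown here, compound 4 also isolates that side chain for the first time: the change of hydrogen to (1-methylpyrrolidin-2-yl)methoxy gives a 2.6-fold lower number from compound 1 to compound 4 (0.42 log units; beyond the scatter), which places the higher number of compound 1 with the missing side chain and not with its 6-methoxypyridin-3-yl group. Nothing available explains either step.

As far as these compounds go, it remains open whether this position would stay as indifferent with a group of another kind, such as an aminomethylphenyl or a carboxylic acid on the ring. It is also open whether the side chain would give a similar step with 4-cyanophenyl in place, since the compounds shown include no partner for that comparison.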